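The source may hold more compounds than are shown below. What is called first, only, known or untested is meant among the compounds shown, and "the series" means these compounds.

Measured compounds:
compound 1 `O=C1C(COCCCl)=CS(=O)(=O)c2ccccc21` with 98.1%
compound 2 `O=C1C(CNc2ccccc2)=CS(=O)(=O)c2ccccc21` with 0%

Both compounds were tested in a functional assay on the whole organism for inhibition, with Mus musculus as the target, at a dose of 10 mg/kg; a lower number here means less inhibition, a higher number more inhibition at the dose given (going by the name of the read-out). On these two numbers compound 2 stands lowest; its nearest neighbour is compound 1, whose value lies higher by a number 98.1 percentage points lower from compound 1 to compound 2 (beyond the scatter) when read backwards, a step the scatter does not cover. Going by the values given here, that single step, anilino in place of 2-chloroethoxy on a saturated chain carbon bound to a double-bonded ring carbon, is the only comparison available.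

Compound 3 `CCNC(=O)OCC1=CS(=O)(=O)c2ccccc2C1=O` has not yet been measured. It differs from compound 2 thus: (ethylcarbamoyl)oxy in place of anilino on a saturated chain carbon bound to a double-bonded ring carbon. Among the compounds with values here, the one known step bears on this change in that it removes the same anilino group and returns an oxygen-linked chain without a ring, as in compound 1. A large upward step in this assay is therefore expected, close in size to the fall seen from compound 1 to compound 2, though its exact extent cannot be read from one pair. Compound 3 is expected to give about 70%, within 20% to 100%, an estimated step of a number 70 percentage points higher from compound 2 to compound 3 (beyond the scatter).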

Compound 3, a percentage reported as inhibition, in the whole organism at one dose (the size of the read-out at that dose, not a potency): 99.3%
Beside the measured number, compound 3's estimate is 29.3 percentage points below it, and the stated range covers the measured number.
By their numbers in this assay, from the lowest: compound 2; then compounds 1 and 3 (each within the scatter of the next).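

In this assay, (ethylcarbamoyl)oxy in place of anilino gives a number 99.3 percentage points higher from compound 2 to compound 3 (beyond the scatter), so a high value at this position, on a saturated chain carbon bound to a double-bonded ring carbon, is not tied to the 2-chloroethoxy group of compound 1. Ethylcarbamoyl in place of 2-chloroethyl on the oxygen gives a number 1.2 percentage points higher from compound 1 to compound 3 (within the scatter), so these two oxygen-linked chains cannot be told apart at this dose, and the 2-chloroethyl chain is not needed for the high value. Nothing available here accounts for why anilino gives so different a value from either oxygen-linked group.

Going by these compounds, whether the low value goes with the nitrogen link or with the aromatic ring of anilino stays open; a phenoxy group and an ethylamino group at this position would separate the two. On these data alone, how far the oxygen-linked chain can change also stays open, for instance with a longer chain or a terminal carboxylic acid.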